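The compounds below may be only part of what the source reports. "The series", "measured", "known", "first", "only" and "open" are said of these compounds alone.

Compound 1 `COC1=C(OC)[C@H](O)[C@H](C/C=C(\C)CC/C=C(\C)C[C@@H]2C[C@@H](C)C(=O)O2)[C@@H](C)C1=O` gives 14100 nM in a functional assay on A549 cells (Homo sapiens) for inhibition, read by sulforhodamine B assay, with a stated time of 48 h; on this read-out higher numbers stand for weaker inhibition of growth and lower numbers for stronger inhibition of growth.
Compound 2 `COC1=C(OC)[C@H](O)[C@H](C/C=C(\C)CC/C=C(\C)C/C=C/C(C)(C)O)[C@@H](C)C1=O` gives 23800 nM in this assay.

Among the measured compounds shown here, compound 2 carries the nominally higher of the two numbers, but the only measured step, a 1.7-fold higher number from compound 1 to compound 2 (0.23 log units; within the scatter), lies within the scatter, so the two compounds cannot be told apart. Compound 3 `COC1=C(OC)[C@H](O)[C@H](C/C=C(\C)CC/C=C(\C)CCCC(C)CO)[C@@H](C)C1=O` differs from compound 2 by 3-(hydroxymethyl)butyl in place of 3-hydroxy-3-methylbut-1-en-1-yl on a saturated chain carbon bound to a double-bonded chain carbon. For the measured compounds named here, the one step that bears on this change, a 1.7-fold higher number from compound 1 to compound 2 (0.23 log units; within the scatter), sits at the same place on the chain and stayed within the scatter, so no step beyond the scatter is expected here in this assay. Compound 3 is therefore expected to give about 20000 nM, in a range from 8000 nM to 50000 nM, which means an expected step of a 1.2-fold lower number from compound 2 to compound 3 (0.08 log units; within the scatter).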

Compound 3, concentration for 50% growth inhibition: 7100 nM
For compound 3 the middle estimate is 2.8-fold (0.45 log units) above the measured one, outside the stated range (below it).
By their numbers in this assay, from the lowest: compounds 3, 1 and 2 (each within the scatter of the next, the first and the last beyond it).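

Among the compounds shown here, replacing 3-hydroxy-3-methylbut-1-en-1-yl with 3-(hydroxymethyl)butyl gives the first step beyond the scatter at this place in this assay, a 3.4-fold lower number from compound 2 to compound 3 (0.53 log units; beyond the scatter), so this chain position responds to a change that keeps the heavy-atom count the same. The other new step, a 2.0-fold lower number from compound 1 to compound 3 (0.30 log units; within the scatter), stays within the scatter, so compound 3 cannot be told apart from compound 1. Nothing at hand accounts for the step from compound 2.

The change removes the double bond and moves the hydroxyl together, so the compounds shown do not separate the two. From the compounds shown here alone, how a carboxylic acid, an amine or a longer chain would fare here remains open.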